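The source may hold more compounds than are shown below. What is called first, only, known or untested is meant among the compounds shown, and "the series" means these compounds.

Within the data shown here, in a functional assay on MCF7 cells (Homo sapiens) for antiproliferative activity, read by sulforhodamine B assay, with a stated time of 48 h (on this read-out lower numbers stand for stronger inhibition of growth and higher numbers for weaker inhibition of growth), compound 3 `FC(F)(F)c1ccc2c(NCCCN3CCCC3)ccnc2c1` gives 36800 nM, the highest number among the three compounds measured so far. Compound 1 `Clc1ccc2c(NCCCN3CCCC3)ccnc2c1` gives 21500 nM, and compound 2 `CN1CCN(CCCNc2ccnc3cc(Cl)ccc23)CC1` gives 17100 nM. The step of a 1.7-fold higher number from compound 1 to compound 3 (0.23 log units; within the scatter) lies within the scatter, so compound 1 and compound 3 cannot be separated on these numbers. Compound 4 `CN1CCN(CCCNc2ccnc3cc(C(F)(F)F)ccc23)CC1` has not yet been measured; it differs from compound 3 by 4-methylpiperazin-1-yl in place of pyrrolidin-1-yl on a saturated chain carbon, three bonds along the chain from a nitrogen on an aromatic ring. Among the measured compounds shown here, the one measured step that bears directly on this change is a 1.3-fold lower number from compound 1 to compound 2 (0.10 log units; within the scatter), and that step too lies within the scatter. On this basis the expected change in this assay is a 1.3-fold lower number from compound 3 to compound 4 (0.12 log units; within the scatter), which is no change beyond the scatter, with at most a slight lean toward a lower number because of a 1.3-fold lower number from compound 1 to compound 2 (0.10 log units; within the scatter). Compound 4 is therefore estimated at 28000 nM in this assay, with a range from 14000 nM to 56000 nM.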

Compound 4, concentration for 50% growth inhibition: 30800 nM
The estimate for compound 4 lay 1.1-fold (0.04 log units) below the measured number; low and high end bracket the measured number.
By their numbers in this assay, from the lowest: compounds 2, 1, 4 and 3 (each within the scatter of the next, the first and the last beyond it).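

In this assay, replacing pyrrolidin-1-yl with 4-methylpiperazin-1-yl on the saturated chain carbon can now be read with trifluoromethyl on the aromatic carbon as well as with chloro, and the new reading (a 1.2-fold lower number from compound 3 to compound 4 (0.08 log units; within the scatter)) agrees with the earlier one: the same change on two cores in this assay, a 1.3-fold lower number (0.10 log units; within the scatter) from compound 1 to compound 2 and a 1.2-fold lower number (0.08 log units; within the scatter) from compound 3 to compound 4, 1.1-fold (0.02 log units) apart, within the scatter of two such steps. Trifluoromethyl in place of chloro on the aromatic carbon also gains a second reading (a 1.8-fold higher number from compound 2 to compound 4 (0.26 log units; within the scatter)), again in agreement with the first: the same change on two cores in this assay, a 1.7-fold higher number (0.23 log units; within the scatter) from compound 1 to compound 3 and a 1.8-fold higher number (0.26 log units; within the scatter) from compound 2 to compound 4, 1.1-fold (0.02 log units) apart, within the scatter of two such steps. Neither change goes beyond the scatter with either partner group, and, as far as these numbers can tell, the outcome of one change does not depend on the other.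

From the compounds shown here alone, whether a morpholin-4-yl or dimethylamino group at the chain end, or a longer chain, would give a step beyond the scatter remains open. The same holds for a fluoro or methoxy group on that aromatic carbon.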